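Chain length at the sulfur: from compound 2 to compound 3

The source may hold more compounds than are shown below. What is called first, only, known or untested is meant among the compounds shown, and "the series" means these compounds.

Measured so far in a functional assay on L1210 cells (Mus musculus) for inhibition, tested at 0.5 mM; a lower number here means less inhibition, a higher number more inhibition at the concentration tested (going by the name of the read-out):
compound 1 `C[S+](=N)([O-])CCC(NC(=O)c1ccc(NCc2cnc3nc(N)nc(O)c3n2)cc1)C(=O)O` gives 76.4%
compound 2 `CCC[S+](=N)([O-])CCC(NC(=O)c1ccc(NCc2cnc3nc(N)nc(O)c3n2)cc1)C(=O)O` gives 75.2%

Among the measured compounds shown here, compound 2 stands lowest of the two numbers in this assay, but the only step, a number 1.2 percentage points lower from compound 1 to compound 2 (within the scatter), lies within the scatter, so the two compounds cannot be ordered. Compound 3 `CCCC[S+](=N)([O-])CCC(NC(=O)c1ccc(NCc2cnc3nc(N)nc(O)c3n2)cc1)C(=O)O` differs from compound 2 by methyl in place of hydrogen on a saturated chain carbon, three bonds along the chain from a sulfur. For the measured compounds named here, the one measured step that bears on this change is a number 1.2 percentage points lower from compound 1 to compound 2 (within the scatter), a chain lengthening at the same position that produced no change beyond the scatter. The expected step is therefore a number 1.2 percentage points lower from compound 2 to compound 3 (within the scatter), with no direction claimed. Compound 3 is estimated at 74%, with a range from 60% to 86%.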

Compound 3, a percentage reported as inhibition, at one concentration (the size of the read-out at that concentration, not a potency): 75.2%
Estimate against measurement, compound 3: 1.2 percentage points below; measured number inside the range.
By their numbers in this assay, from the lowest: compounds 2, 3 and 1 (each within the scatter of the next).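

In this assay, a further lengthening of the chain on the sulfur reads no change at the digits printed from compound 2 to compound 3 (within the scatter), and the full span of the series, butyl against methyl, reads a number 1.2 percentage points lower from compound 1 to compound 3 (within the scatter). Across this short set of straight chains, the read-out therefore stays within the scatter over two successive additions, not just one. No supporting measurement bears on this result. Still open, on these data alone, is how the position answers to a chain longer than butyl, or to a chain ending in an amine or a carboxylic acid. A single tested concentration also leaves any potency difference among these compounds unresolved.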